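Amide substituent swap on a shared triazole-carboxamide series

This account rests on a few compounds, and the source may have more. Where it says the series, first, only, none or still open, it means among the compounds named here.

Measured so far in a functional assay on the whole organism for inhibition, with Rattus norvegicus as the target, read by paw edema, with stated times of 30 min and 2 h, at a dose of 0.28 mmol/kg by the oral route; a higher number here means more inhibition at the dose given (going by the name of the read-out), a lower number less inhibition:
compound 1, `COc1ccc(-n2nc(C(N)=O)nc2-c2cc(OC)c(OC)c(OC)c2)cc1`, 59%
compound 2, `COc1ccc(-n2nc(C(=O)Nc3ccc(C)cc3)nc2-c2cc(OC)c(OC)c(OC)c2)cc1`, 60%

Compound 2 gives the higher of the two numbers, but the step between them is a number 1 percentage points higher from compound 1 to compound 2 (within the scatter), so the two values are within the scatter of each other and no order between them can be read. For the measured compounds named here, compound 2 therefore stands simply as one of two equivalent points, and the only measured step shows that putting 4-methylphenyl on the amide-type nitrogen in place of hydrogen left this assay unchanged.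

Compound 3, `COc1ccc(-n2nc(C(=O)Nc3ccccc3C)nc2-c2cc(OC)c(OC)c(OC)c2)cc1`, is not yet measured. It differs from compound 2 by 2-methylphenyl in place of 4-methylphenyl on an amide-type nitrogen. Going by the values given here, no measured step moves the methyl group around the phenyl ring, so the only bearing evidence is the step from compound 1 to compound 2, which was within the scatter. On that basis a step beyond the scatter is not expected in this assay from compound 2 to compound 3, estimated as a number 2 percentage points lower from compound 2 to compound 3 (within the scatter). Compound 3 is accordingly expected to give about 58% in this assay, in the range 42% to 72%.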

Compound 3, a percentage reported as inhibition, in the whole organism at one dose (the size of the read-out at that dose, not a potency): 30%
Estimate against measurement, compound 3: 28 percentage points above, outside the stated range (below it).
By their numbers in this assay, from the lowest: compound 3; then compounds 1 and 2 (each within the scatter of the next).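

At the amide-type nitrogen, the choice of aryl group now counts in this assay: 2-methylphenyl in place of 4-methylphenyl, with the same atoms and the same counts on both groups, gives a number 30 percentage points lower from compound 2 to compound 3 (beyond the scatter), so where the methyl group sits on the phenyl ring matters, which the earlier step could not show. Against the unsubstituted amide, 2-methylphenyl in place of hydrogen gives a number 29 percentage points lower from compound 1 to compound 3 (beyond the scatter), while 4-methylphenyl at the same nitrogen stayed within the scatter of compound 1, so among these three compounds, replacing the amide hydrogen with a methylphenyl group can either leave the read-out unchanged or lower it, depending on the isomer. Nothing available here bears on why the two isomers differ.

From the compounds shown here alone, it remains open whether this drop is specific to 2-methylphenyl or extends to other groups in that form, such as 2-chlorophenyl or 2-methoxyphenyl, and where 3-methylphenyl or plain phenyl would fall in this assay. Also open, going by these compounds, is whether a small alkyl group such as methyl or ethyl on the same nitrogen would stay level with compound 1 or fall toward compound 3.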